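This account rests on a few compounds, and the source may have more. Where it says the series, first, only, none or still open, it means among the compounds named here.

Measured so far in a functional assay on A-375 cells (Homo sapiens) for antiproliferative activity, read by CCK-8 assay, with a stated time of 72 h, tested at 8 uM; on this read-out higher numbers stand for a stronger effect at the one concentration tested and lower numbers for a weaker effect:
compound 1 `Nc1ccccc1NC(=O)c1ccc(CSC(=S)N2CCN(c3ccc(Cl)cc3)CC2)cc1` gives 29%
compound 2 `CN(Cc1ccncc1)C(=S)SCc1ccc(C(=O)Nc2ccccc2N)cc1` gives 86.1%
compound 3 `Nc1ccccc1NC(=O)c1ccc(CSC(=S)N2CCN(c3ccc(F)cc3)CC2)cc1` gives 76.3%

Compound 3 stands second of the three numbers. Its value and that of compound 2 lie within the scatter of each other, so no order between these two can be read. Against compound 1 the gap is clear: a number 47.3 percentage points higher from compound 1 to compound 3 (beyond the scatter), a large step for the exchange of a single halogen on the aryl ring.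

Compound 4 `Cc1ccc(N2CCN(C(=S)SCc3ccc(C(=O)Nc4ccccc4N)cc3)CC2)cc1` is not yet measured. It differs from compound 3 in one place: methyl in place of fluoro on an aromatic carbon. Going by the values given here, the only measured step that bears on this is the one from compound 1 to compound 3, which changed the group at this same aromatic carbon and was large. Among the compounds with values here, no step with methyl at this position exists, so the direction of the change from fluoro to methyl is not fixed by the data; the one comparison shows only that this position is sensitive, with a large swing between two halogens.

The expectation for compound 4 is therefore wide. A step of a number 18.3 percentage points lower from compound 3 to compound 4 (beyond the scatter) is estimated, leaning slightly downward given that the departure from fluoro in the measured pair went with the low value of compound 1 29%. Compound 4 is estimated at 58%, within a range of 25% to 88%.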

Compound 4, a percentage reported as inhibition, at one concentration (the size of the read-out at that concentration, not a potency): 26.4%
Compound 4: the middle estimate sits 31.6 percentage points above what was measured; the range from low to high includes it.
By their numbers in this assay, from the lowest: compounds 4 and 1 (each within the scatter of the next); then compounds 3 and 2 (each within the scatter of the next).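

In this assay, the exchange to 4-methylphenyl gives a second large step at this aromatic carbon, a number 49.9 percentage points lower from compound 3 to compound 4 (beyond the scatter), so the sensitivity of this position is not confined to a swing between two halogens. With a number 2.6 percentage points lower from compound 1 to compound 4 (within the scatter), the methyl and chloro compounds cannot be told apart, and among compounds 1, 3 and 4 only the fluoro compound carries a high value. Nothing available explains why fluoro parts from the other two groups.

The compounds shown leave open whether fluoro is the exception on this carbon or whether chloro and methyl are, since hydrogen, a methoxy group or an amine at the same place would fall on one side or the other. They also leave open whether this split holds at any concentration other than the one tested.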